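Swapping 4-nitrophenyl for 3-aminophenyl in compound 3

This account rests on a few compounds, and the source may have more. Where it says the series, first, only, none or still open, it means among the compounds named here.

Measured in a functional assay on MCF7 cells (Homo sapiens) for cytotoxicity, read by MTT assay, with a stated time of 96 h; a higher number here means a weaker inhibitor, a lower number a stronger inhibitor:
Compound 1 `COc1cc(C(=O)c2cn(-c3ccc(N)cc3)cc2-c2ccccc2Cl)cc(OC)c1OC`: 83 nM
Compound 2 `COc1cc(C(=O)c2cn(-c3ccc(N)cc3)cc2-c2cccc([N+](=O)[O-])c2)cc(OC)c1OC`: 260 nM
Compound 3 `COc1cc(C(=O)c2cn(-c3ccc(N)cc3)cc2-c2ccc([N+](=O)[O-])cc2)cc(OC)c1OC`: 260 nM

Compound 3 gives 260 nM, the same number as compound 2 at 260 nM. Among the measured compounds shown here, these two share the highest number of the three, and the only lower number belongs to compound 1, which gives 83 nM.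

The next compound is compound 4 `COc1cc(C(=O)c2cn(-c3ccc(N)cc3)cc2-c2cccc(N)c2)cc(OC)c1OC`, which carries 3-aminophenyl in place of 4-nitrophenyl on an aromatic carbon. For the measured compounds named here, no measured pair exchanges a nitrophenyl for an aminophenyl, so the evidence is indirect. Three measured steps change the group at this same place. The step between the two nitrophenyl compounds is no change at the digits printed from compound 2 to compound 3 (within the scatter). The two steps away from the 2-chlorophenyl of compound 1 are a 3.1-fold higher number from compound 1 to compound 2 (0.50 log units; beyond the scatter) and a 3.1-fold higher number from compound 1 to compound 3 (0.50 log units; beyond the scatter), both modest.

A step of similar modest size is therefore expected in this assay. Going by the values given here, its direction is uncertain, but a lower number is favoured, since the only change at this place that separates the values involves compound 1 at 83 nM, which lies below compound 3. The estimated step is a 2.2-fold lower number from compound 3 to compound 4 (0.34 log units; beyond the scatter). For compound 4 the expected value is 120 nM, with an estimated range of 30 nM to 450 nM.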

Compound 4, half-maximal inhibitory concentration: 78 nM
For compound 4 the middle estimate is 1.5-fold (0.19 log units) above the measured one, within the range that was stated.
By their numbers in this assay, from the lowest: compounds 4 and 1 (each within the scatter of the next); then compounds 2 and 3 (each within the scatter of the next).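

In this assay the series now holds a direct exchange of nitro for amino on the same aromatic carbon of the five-membered ring, and it moves the number beyond the scatter (a 3.3-fold lower number from compound 2 to compound 4 (0.52 log units; beyond the scatter)). The earlier compounds shown here showed only that the 3-nitrophenyl and 4-nitrophenyl groups were level and that the 2-chlorophenyl group of compound 1 gave the lower number, whereas compound 4 now gives a step of the same printed size against the 4-nitrophenyl compound (a 3.3-fold lower number from compound 3 to compound 4 (0.52 log units; beyond the scatter)). The low number at this place is therefore not confined to the 2-chlorophenyl group, since 3-aminophenyl stands level with it within the scatter (a 1.1-fold lower number from compound 1 to compound 4 (0.03 log units; within the scatter)), and this place tolerates two quite different substituted phenyl groups in the low range.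

The compounds shown leave open whether 2-aminophenyl or 4-aminophenyl, or a hydroxyl or methoxy group in place of the amino of compound 4, would keep the number at this level. Nothing measured here accounts for the size or direction of these steps.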